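The source may report more compounds than this note shows. Statements on the series, on what has been measured and on what is new or still open speak of the compounds shown alone.

Compound 2 `COc1cc(C2CC(=NOC(=O)c3ccc(F)cc3)CC(c3ccc(O)c(OC)c3)N2C)ccc1O` gives 141000 nM in a functional assay, read by spectrophotometry, with a stated time of 30 min; a lower number here means a stronger inhibitor, a higher number a weaker inhibitor. Among the two numbers shown it stands highest, and its nearest neighbour is compound 1 `COc1cc(C2CC(=NOC(=O)c3ccc([N+](=O)[O-])cc3)CC(c3ccc(O)c(OC)c3)N2C)ccc1O`, which in this assay gives 79000 nM; the two lie within the scatter, as a 1.8-fold higher number from compound 1 to compound 2 (0.25 log units; within the scatter) shows. Compound 3 `COc1cc(C2CC(=NO)CC(c3ccc(O)c(OC)c3)N2C)ccc1O` differs from compound 2 in one place: hydrogen in place of (4-fluorophenyl)carbonyl on an oxygen. For the measured compounds named here, no measured step touches this position; the only step in hand, a 1.8-fold higher number from compound 1 to compound 2 (0.25 log units; within the scatter), exchanges one aromatic substituent for another and leaves the ester intact, so it offers no guide to removing the (4-fluorophenyl)carbonyl group altogether. The expectation therefore rests on compound 2 alone, and a step of size a 1.4-fold lower number from compound 2 to compound 3 (0.15 log units; within the scatter) is expected, with wide uncertainty. Compound 3 is estimated at 100000 nM in this assay, with a range from 25000 nM to 400000 nM.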

Compound 3, half-maximal inhibitory concentration: 158000 nM
Beside the measured number, compound 3's estimate is 1.6-fold (0.20 log units) below it; low and high end bracket the measured number.
By their numbers in this assay, from the lowest: compounds 1, 2 and 3 (each within the scatter of the next).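

Replacing the (4-fluorophenyl)carbonyl group on this oxygen with hydrogen gives a 1.1-fold higher number from compound 2 to compound 3 (0.05 log units; within the scatter) in this assay, and replacing the (4-nitrophenyl)carbonyl group there gives a 2.0-fold higher number from compound 1 to compound 3 (0.30 log units; within the scatter). Thus, where the earlier step only exchanged one aromatic substituent for another, these steps remove the whole group, and in neither case does the number move beyond the scatter, so among these three compounds this assay does not separate either carbonyl group from hydrogen on this oxygen. No supporting measurement is available to explain this result.

Going by these compounds, it remains open whether a small acetyl group, a methyl ether or a longer chain on this oxygen would give a number beyond the scatter of these three compounds. The same question stands for an amine or a carboxylic acid on the aromatic ring of the ester.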